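A few compounds are considered here, and "the series" means these few. Any claim that something is new, unique, unknown or untested is made for them only; others in the source may bear on it.

Compound 1 `CCN(CC(=O)NC[C@H]1O[C@H](OC)[C@@H](OS(=O)(=O)O)[C@@H](OS(=O)(=O)O)[C@@H]1OS(=O)(=O)O)C(=O)CCCCC(=O)O` is tested in an assay on isolated protein for binding affinity to fibroblast growth factor 2 (Homo sapiens), read by surface plasmon resonance (a lower number here means tighter binding, a higher number weaker binding), where compound 1 gives 480000 nM. Compound 2 `CO[C@H]1O[C@H](CNC(=O)CN(C(C)=O)c2ccccc2)[C@@H](OS(=O)(=O)O)[C@H](OS(=O)(=O)O)[C@@H]1OS(=O)(=O)O` gives 480000 nM in this assay, and the step of no change at the digits printed from compound 1 to compound 2 (within the scatter) shows no change, so compound 1 stands level with compound 2. The unmeasured compound 3 `CO[C@H]1O[C@H](CNC(=O)CN(CCOS(=O)(=O)O)C(C)=O)[C@@H](OS(=O)(=O)O)[C@H](OS(=O)(=O)O)[C@@H]1OS(=O)(=O)O` differs from compound 1 by acetyl(2-(sulfooxy)ethyl)amino in place of ((4-carboxybutyl)carbonyl)(ethyl)amino on a saturated chain carbon bound to a carbonyl carbon. Within the data shown here, the one step that bears on this kind of exchange at this position, from compound 1 to compound 2, was flat, so little movement beyond the scatter is expected, and the step of a 1.4-fold lower number from compound 1 to compound 3 (0.14 log units; within the scatter) is estimated to be small. Compound 3 is expected to give 350000 nM, within 120000 nM to 1000000 nM.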

Compound 3, dissociation constant: 240000 nM
Compound 3: middle estimate off by 1.5-fold (0.16 log units), on the high side; low and high end bracket the measured number.
By their numbers in this assay, from the lowest: compounds 3, 1 and 2 (each within the scatter of the next).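

In this assay, a third kind of group on this saturated chain carbon bound to a carbonyl carbon, acetyl(2-(sulfooxy)ethyl)amino, also stays within the scatter, with a 2.0-fold lower number from compound 1 to compound 3 (0.30 log units; within the scatter). Exchanging phenyl for 2-(sulfooxy)ethyl on the amide-type nitrogen gives a 2.0-fold lower number from compound 2 to compound 3 (0.30 log units; within the scatter), so adding a sulfooxy group to this side chain shows no clear gain over either earlier compound. Nothing available explains why these different groups read alike.

From the compounds shown here alone, whether an amine or a hydroxyl on this side chain, or a longer chain ending in sulfooxy, would move the number beyond the scatter remains open.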